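Extending the Ester Chain of Compound 3

The compounds below may be only part of what the source reports. "The series", "measured", "known", "first", "only" and "open" are said of these compounds alone.

Of the compounds shown here, three sharing one core have been tested in a functional assay on HEK293 cells for antagonist activity at Voltage-dependent L-type calcium channel subunit alpha-1C (Oryctolagus cuniculus), read by FLIPR; a higher number here means a weaker inhibitor, a lower number a stronger inhibitor. Compound 1 `CCCC1=C(C(=O)OCC)C(c2cccc([N+](=O)[O-])c2)C(C(=O)OCC)=C(C)N1` gives 18 nM. Compound 2 `C=CCOC(=O)C1=C(C)NC(C)=C(C(=O)OC)C1c1cccc([N+](=O)[O-])c1` gives 15 nM, and compound 3 `C=CCOC(=O)C1=C(C)NC(C)=C(C(=O)OCC)C1c1cccc([N+](=O)[O-])c1` gives 25 nM. Compound 3 carries the highest number of the three, yet its gaps to compound 1 and to compound 2 both lie within the scatter of repeated measurements, so the three cannot be ranked against each other on these numbers.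

Compound 4 `CCCCCOC(=O)C1=C(C)NC(C)=C(C(=O)OCC)C1c1cccc([N+](=O)[O-])c1` has not yet been measured. It differs from compound 3 in one place: butyl in place of vinyl on a saturated chain carbon bound to an oxygen next to a carbonyl group. Going by the values given here, the only measured step that changes a single position is a 1.7-fold higher number from compound 2 to compound 3 (0.22 log units; within the scatter), which also alters an ester chain on the shared core and left the number essentially where it was. Among the compounds with values here, that step is the closest guide available, although the present change is a larger one and the data hold no example of a chain of this length at this position. On this basis the step from compound 3 to compound 4 is expected to be small, no change at the digits printed from compound 3 to compound 4 (within the scatter), with no clear direction beyond the scatter. Compound 4 is therefore estimated to give 25 nM in this assay, within a range from 9 nM to 70 nM.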

Compound 4, half-maximal inhibitory concentration: 49 nM
The estimate for compound 4 lay 2.0-fold (0.29 log units) below the measured number; low and high end bracket the measured number.
By their numbers in this assay, from the lowest: compounds 2, 1, 3 and 4 (each within the scatter of the next, the first and the last beyond it).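

Going by these compounds alone, replacing vinyl with butyl gives a 2.0-fold higher number from compound 3 to compound 4 (0.29 log units; within the scatter) in this assay, which is the first reading on this ester chain itself, since the earlier single-place step altered the ester on the other side of the shared core. Even with butyl in place of vinyl, the number stays inside the usual scatter, so this one step gives no sign that the longer saturated chain changes the result at this position. The swap makes two changes at once, lengthening the chain and removing its double bond, and a single step cannot separate them, while no supporting measurement is available to explain the result.

Going by these compounds, what remains open is how the chain behaves when only one of those two features changes, as ethyl in place of vinyl would show by removing the double bond without adding length. Also unanswered is whether this position would keep its number with a longer chain such as octyl, or with a chain ending in an amine or a carboxylic acid.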